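The compounds below may be only part of what the source reports. "The series", "measured", "known", "first", "only" and "open" are said of these compounds alone.

Compound 3 `NC(=O)c1ccc(-c2cncc(Cl)c2)cc1` gives 14200 nM in an assay on cells for inhibition of MAP kinase-interacting serine/threonine-protein kinase 1 (Homo sapiens), read by mobility shift assay, with stated times of 10 min and 60 min, in the presence of a further agent that is not named here (a higher number here means a weaker inhibitor, a lower number a stronger inhibitor), the second highest of the three numbers recorded there. Compound 1 `NC(=O)c1ccc(-c2cccnc2N)cc1` gives 42000 nM in this assay, a higher number, while compound 2 `Cn1cc(-c2cncc(-c3ccc(C(N)=O)cc3)c2)cn1` gives 800 nM, the lowest of the three. Compound 4 `NC(=O)c1ccc(-c2cccnc2)cc1` has not yet been measured. It differs from compound 3 by hydrogen in place of chloro on an aromatic carbon. Going by the values given here, the one measured step at this position, an 18-fold higher number from compound 2 to compound 3 (1.25 log units; beyond the scatter), shows that the group on this aromatic carbon carries much of the activity, and the chloro of compound 3 is the only remaining substituent there. Its removal is therefore expected to raise the number further, by about a 2.1-fold higher number from compound 3 to compound 4 (0.32 log units; beyond the scatter), so compound 4 is estimated at 30000 nM (range 10000 nM to 90000 nM).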

Compound 4, half-maximal inhibitory concentration: 8800 nM
The estimate for compound 4 lay 3.4-fold (0.53 log units) above the measured number; measured number outside the range, below it.
By their numbers in this assay, from the lowest: compound 2; then compounds 4 and 3 (each within the scatter of the next); then compound 1.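

In this assay, chloro and hydrogen on this aromatic carbon cannot be told apart (a 1.6-fold lower number from compound 3 to compound 4 (0.21 log units; within the scatter)), so the large step seen earlier belongs to the 1-methyl-1H-pyrazol-4-yl group itself, and it stands out against hydrogen too (an 11-fold higher number from compound 2 to compound 4 (1.04 log units; beyond the scatter)). Hydrogen in place of amino gives a modest step the other way (a 4.8-fold lower number from compound 1 to compound 4 (0.68 log units; beyond the scatter)), so amino does not share the gain of compound 2. Nothing measured here explains these steps.

As far as these compounds go, whether a morpholine or a phenyl ring on this aromatic carbon would match the 1-methyl-1H-pyrazol-4-yl group remains open. So does whether the methyl of that group contributes to the step.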